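Methoxy in Place of Methyl: Expected Cytotoxicity of Compound 3

The source may report more compounds than this note shows. Statements on the series, on what has been measured and on what is new or still open speak of the compounds shown alone.

Measured compounds:
- compound 1, `O=C(CCC(=O)OCCCCCCSc1ccc([N+](=O)[O-])c2nonc12)Nc1ccc(F)cc1`, gives 6460 nM in an ADME assay on L02 cells (Homo sapiens) for cytotoxicity, read by MTT assay, with a stated time of 72 h; on this read-out lower numbers stand for stronger inhibition and higher numbers for weaker inhibition
- compound 2, `Cc1ccc(NC(=O)CCC(=O)OCCCCCCSc2ccc([N+](=O)[O-])c3nonc23)cc1`, gives 7320 nM in this assay
- compound 3, `COc1ccc(NC(=O)CCC(=O)OCCCCCCSc2ccc([N+](=O)[O-])c3nonc23)cc1`, not yet measured

Of the compounds shown here, two have been measured so far, and compound 2 has the higher of the two numbers in this assay; its nearest neighbour is compound 1, and the gap between them is within the scatter, so the two cannot be told apart.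

Compound 3 differs from compound 2 in one place: methoxy in place of methyl on an aromatic carbon. Among the compounds with values here, the only measured step that bears on this position is the one from compound 1 to compound 2, which swapped fluoro for methyl on the same aromatic carbon and gave a 1.1-fold higher number from compound 1 to compound 2 (0.05 log units; within the scatter). That step did not move the number beyond the scatter, so a second small change at the same place is not expected to either.

Compound 3 is therefore expected to show a 1.0-fold lower number from compound 2 to compound 3 (0.02 log units; within the scatter), a step within the scatter. The estimate for compound 3 in this assay is 7000 nM, with a range from 3500 nM to 14000 nM.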

Compound 3, half-maximal inhibitory concentration: 8170 nM
Compound 3: the middle estimate sits 1.2-fold (0.07 log units) below what was measured, and the stated range covers the measured number.
By their numbers in this assay, from the lowest: compounds 1, 2 and 3 (each within the scatter of the next).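

In this assay, replacing methyl with methoxy on this aromatic carbon gives a 1.1-fold higher number from compound 2 to compound 3 (0.05 log units; within the scatter) and brings in an oxygen atom and a hydrogen-bond acceptor, yet the number cannot be told apart from that of compound 2. The comparison with the fluoro compound gives a 1.3-fold higher number from compound 1 to compound 3 (0.10 log units; within the scatter) and so links the two ends of the series directly, which shows that even this larger swap at the position does not separate the compounds. Three different groups have now been tried on the same aromatic carbon, and all three compounds remain within the scatter of one another, so the earlier single step now has two further steps in agreement with it, though nothing shown here offers an explanation for this flat result.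

What the compounds leave open is whether a group of another kind on this aromatic carbon, such as an amine or a carboxylic acid, or a longer chain such as butoxy in place of methoxy, would move the number beyond the scatter. They also leave open whether the same flat picture would hold if the group sat elsewhere on the six-membered ring.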